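The source may report more compounds than this note shows. Statements on the series, on what has been measured and on what is new or still open speak of the compounds shown alone.

Working notes on the series. Compound 1 `O=C1Nc2ccccc2/C1=C/c1ccc(-c2cn(-c3cccc(F)c3)nn2)cc1` is measured in an ADME assay on HUVEC cells (Homo sapiens) for inhibition, read by CCK-8 assay, with a stated time of 24 h, in the presence of a further agent that is not named here (on this read-out higher numbers stand for weaker inhibition and lower numbers for stronger inhibition), and gives only a limit of the assay, > 20000 nM (the limit of > 20000 nM in this assay, at which 1 of the 3 values shown sits). Compound 2 `O=C1Nc2ccccc2/C1=C/c1ccc(-c2cn(-c3ccc(F)cc3)nn2)cc1` gives 14700 nM in this assay; the change 4-fluorophenyl in place of 3-fluorophenyl on an aromatic nitrogen gives an at least 1.3-fold lower number from compound 1 to compound 2 (0.13 log units; that floor lies within the scatter). Compound 3 `O=C1Nc2ccc(F)cc2/C1=C/c1ccc(-c2cn(-c3cccc(F)c3)nn2)cc1` gives 17300 nM in this assay; its core differs from that of compound 1 by fluoro in place of hydrogen on an aromatic carbon, and the step is an at least 1.1-fold lower number from compound 1 to compound 3 (0.06 log units; that floor lies within the scatter). Compound 3 and compound 2 sit within the scatter of one another.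

Compound 4 `O=C1Nc2ccc(F)cc2/C1=C/c1ccc(-c2cn(-c3ccc(F)cc3)nn2)cc1` is not yet measured in this assay. It carries the same change as compound 2 carries against compound 1, (4-fluorophenyl in place of 3-fluorophenyl on an aromatic nitrogen), here on the fluoro-bearing core; the place of the change reads the same in both pairs. Since the earlier step was only a floor from a limit, a small step is expected from compound 3 to compound 4, a 1.2-fold lower number from compound 3 to compound 4 (0.09 log units; within the scatter). This rests on compound 2, whose value 14700 nM lies within the scatter of compound 3. Compound 4 is therefore expected to give about 14000 nM, estimated between 7000 nM and 25000 nM.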

Compound 4, half-maximal inhibitory concentration: > 20000 nM
Compound 4: only a limit was reported; the forecaster's own chance of this, stated with the estimate: 25%; at least 1.4-fold (0.15 log units) between middle value and limit.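

In this assay, from the compounds shown here alone, the step of an at least 1.1-fold higher number from compound 3 to compound 4 (0.06 log units; that floor lies within the scatter) sets 4-fluorophenyl in place of 3-fluorophenyl on the fluoro-bearing core, and the comparison with the other core stays open: the same change on two cores in this assay, an at least 1.3-fold lower number (0.13 log units; that floor lies within the scatter) from compound 1 to compound 2 and an at least 1.1-fold higher number (0.06 log units; that floor lies within the scatter) from compound 3 to compound 4; the limit leaves it open whether they differ. The step of an at least 1.3-fold higher number from compound 2 to compound 4 (0.13 log units; that floor lies within the scatter) gives the same kind of reading for fluoro in place of hydrogen on an aromatic carbon: the same change on two cores in this assay, an at least 1.1-fold lower number (0.06 log units; that floor lies within the scatter) from compound 1 to compound 3 and an at least 1.3-fold higher number (0.13 log units; that floor lies within the scatter) from compound 2 to compound 4; the limit leaves it open whether they differ. Both steps are floors set by a limit, so the data neither show that either change carries over from one core to the other nor show that it fails to.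

Going by these compounds, the actual values of the compounds at the limit remain open: the limit of > 20000 nM in this assay, at which 2 of the 4 values shown sit. On these data alone, how an amine or a carboxylic acid in place of the fluoro on the phenyl group would read in this assay also remains open.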